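Fluoro in place of chloro: a small step expected

This account rests on a few compounds, and the source may have more. Where it says the series, first, only, none or still open, it means among the compounds named here.

Of the compounds shown here, two have so far been measured in an ADME assay on MT4 cells (Homo sapiens) for cytotoxicity, read by spectrophotometry, with a stated time of 5 days (a higher number here means that more compound is tolerated, a lower number that less compound is tolerated), as the read-out of tolerance. Compound 1 (`CN(C)CN1C(=O)/C(=N\NC(=S)NO)c2cc(F)ccc21`) gives 599000 nM there, and compound 2 (`CCN(CC)CN1C(=O)/C(=N\NC(=S)NO)c2cc(Cl)ccc21`) gives 562000 nM in the same test. These two numbers lie within the usual scatter of each other, so compound 2 stands level with compound 1.

Compound 3 (`CCN(CC)CN1C(=O)/C(=N\NC(=S)NO)c2cc(F)ccc21`) has not yet been measured. The change from compound 2 to compound 3 is fluoro in place of chloro on an aromatic carbon. Among the compounds with values here, no measured pair differs in one place only, so no direct precedent exists for this exchange. Within the data shown here, the only guide is compound 2 at 562000 nM, a number within the scatter of compound 1 at 599000 nM in this test. The step of a 1.0-fold higher number from compound 2 to compound 3 (0.01 log units; within the scatter) in this assay is therefore expected to stay within the scatter, with neither direction favoured. For compound 3 an estimated 580000 nM is expected, within a range of 300000 nM to 1000000 nM on repeated measurement.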

Compound 3, half-maximal cytotoxic concentration: 521000 nM
For compound 3 the middle estimate is 1.1-fold (0.05 log units) above the measured one; measured number inside the range.
By their numbers in this assay, from the lowest: compounds 3, 2 and 1 (each within the scatter of the next).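

With compound 3 the series gains its first pairs that differ in one place. In this assay, fluoro in place of chloro on an aromatic carbon gives a 1.1-fold lower number from compound 2 to compound 3 (0.03 log units; within the scatter), so at this position, on the six-membered aromatic ring, the two groups cannot be told apart in this test. Diethylamino in place of dimethylamino on a saturated chain carbon bound to an amide-type nitrogen in a ring gives a 1.1-fold lower number from compound 1 to compound 3 (0.06 log units; within the scatter), which is also within the scatter, so neither single exchange separates the compounds, and no measurement at hand bears on why their numbers stand level.

On these data alone, whether this aromatic position accepts more than these two groups stays open, since a methoxy group, a nitro group or a plain hydrogen there could read differently, and the same holds for a ring amine such as morpholine or piperidine in place of diethylamino. The three compounds also speak only to this assay, and they leave open how the same exchanges would read in any other test.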